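This account rests on a few compounds, and the source may have more. Where it says the series, first, only, none or still open, it means among the compounds named here.

Compound 1 `Cc1ccc(N2CCN(Cn3nc(-c4ccc5c(c4)OCCO5)oc3=S)CC2)c(C)c1`, compound 2 `Fc1ccccc1N1CCN(Cn2nc(-c3ccc4c(c3)OCCO4)oc2=S)CC1` and compound 3 `Fc1ccc(N2CCN(Cn3nc(-c4ccc5c(c4)OCCO5)oc3=S)CC2)cc1` share one core and differ only in the aryl group on the amine nitrogen in the ring. In a functional assay on SW 1116 cells (Homo sapiens) for antiproliferative activity, read by MTT assay, with a stated time of 48 h (on this read-out higher numbers stand for weaker inhibition and lower numbers for stronger inhibition), compound 1 gives > 50000 nM, which is a limit of the assay and not a number. Compound 2 gives 37800 nM. Compound 3 gives > 50000 nM, again a limit. Compound 3 therefore stands only at a limit. The step of an at least 1.3-fold higher number from compound 2 to compound 3 (0.12 log units; that floor lies within the scatter) is at least small, and the step that the two limits leave unreadable from compound 1 to compound 3 cannot be read, since two of the three values sit at the limit of > 50000 nM in this assay, at which 2 of the 3 values shown sit.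

Compound 4 `O=[N+]([O-])c1ccc(N2CCN(Cn3nc(-c4ccc5c(c4)OCCO5)oc3=S)CC2)cc1` carries nitro in place of fluoro on an aromatic carbon. Going by the values given here, no measured step exchanges fluoro for nitro, so nothing gives the size of this change. Compound 4 is expected to show a step that the limit leaves unreadable from compound 3 to compound 4, nothing beyond the scatter. Compound 4 is thus estimated at 60000 nM, between 20000 nM and 200000 nM, most likely again reported as a limit.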

Compound 4, half-maximal inhibitory concentration: > 50000 nM
Compound 4: a limit, no number; the forecaster's own chance of this, stated with the estimate: 70%; the middle value lies beyond the limit too.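

In this assay compound 4 gives > 50000 nM as a limit of the assay and not a number, so nitro in place of fluoro on this aromatic carbon, para to a large group, yields no number. Going by these compounds alone, the one step with a readable floor is an at least 1.3-fold higher number from compound 2 to compound 4 (0.12 log units; that floor lies within the scatter) and so shows no difference beyond the scatter. The other two steps to compound 4 cannot be read, because both ends of each sit at a limit: the limit of > 50000 nM in this assay, at which 3 of the 4 values shown sit.

Left open is whether nitro and fluoro differ here at all, and whether an amino group or a carboxylic acid on this aromatic carbon would give a number within the range of the assay.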